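Geometry of the second alkenyl chain in the cationic series

This account rests on a few compounds, and the source may have more. Where it says the series, first, only, none or still open, it means among the compounds named here.

Measured so far:
compound 1 `CCCCCCCC/C=C\c1c(C)cc(C)nc1CCCOC` — 31.7 uM
compound 2 `CCCCCCCC/C=C\c1c(C)c(/C=C/CCCCCCCC)c2[n+](c1C)CCC2` — 2.2 uM

In a functional assay on M12 cells (Homo sapiens) for antiproliferative activity, read by WST assay, with a stated time of 72 h (on this read-out lower numbers stand for an effect already at smaller amounts and higher numbers for an effect only at larger amounts of compound), compound 2 gives 2.2 uM and holds the lowest number of the two measured; compound 1 gives 31.7 uM, a gap beyond the scatter. Compound 3 `CCCCCCCC/C=C\c1c(C)c(/C=C\CCCCCCCC)c2[n+](c1C)CCC2` is not yet measured. Its difference from compound 2: the two compounds have the same atoms and bonds and differ only in configuration as drawn: 1 of 2 stereo elements differ; a double bond is drawn E in compound 2 and Z in compound 3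

Among the compounds with values here, no step between measured compounds covers a change of this kind, so the expectation rests on compound 2 alone. A small step is expected, with no direction favoured beyond the scatter, a 1.2-fold higher number from compound 2 to compound 3 (0.07 log units; within the scatter). Compound 3 is thus estimated at 2.6 uM, expected between 1 uM and 6.5 uM.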

Compound 3, concentration for half-maximal effect: 3.3 uM
Estimate against measurement, compound 3: 1.3-fold (0.10 log units) below; the measured number falls inside the stated range.
By their numbers in this assay, from the lowest: compounds 2 and 3 (each within the scatter of the next); then compound 1.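

In this assay, the second alkenyl chain of the cationic series shows no separation between its two drawn geometries, with a 1.5-fold higher number from compound 2 to compound 3 (0.18 log units; within the scatter). The comparison isolates a single difference: the fact that compounds 2 and 3 differ only in the configuration as drawn. Double-bond geometry at this chain therefore does not distinguish the two compounds on this read-out, something compound 1, which lacks this chain, could not show.

Going by these compounds, whether the geometry of the other alkenyl chain matters in the same way remains open. So does the outcome of a shorter chain, or of a chain ending in a carboxylic acid or an amine, at this position.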